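The source may report more compounds than this note shows. Statements on the series, on what has been measured and on what is new or still open speak of the compounds shown alone.

Series notes. Compound 1 `CNC(=O)c1cc(C(=O)Nc2cnn(C)c2)cc2c1OC[C@H]2c1ccccc1` is run in a physicochemical assay for lipophilicity, at pH 7.4; on this read-out lower numbers stand for lower lipophilicity and higher numbers for higher lipophilicity; compound 1 gives 3.5. Compound 2 `CC[C@@]1(c2ccccc2)COc2c(C(=O)NC)cc(C(=O)N[C@H]3[C@@H]4COC[C@@H]43)cc21` gives 4.2 in this assay, and compound 3 `CNC(=O)c1cc(C(=O)NC2CC2)cc2c1OC[C@@]2(C)c1ccccc1` gives 4. Of the three numbers compound 2 stands highest. Compound 3 sits close to it, a gap within the usual scatter, so no order is read between compound 2 and compound 3. Compound 1 sits well below compound 2, a gap beyond the scatter. Among the measured compounds shown here, no two of these measured compounds differ in a single place, so no step between measured compounds is counted here.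

Compound 4 `CNC(=O)c1cc(C(=O)N[C@H]2[C@@H]3COC[C@@H]32)cc2c1OC[C@@]2(CO)c1ccccc1` is not yet measured in this assay. It differs from compound 2 by hydroxy in place of methyl on a saturated chain carbon bound to a saturated ring carbon; cut one bond further out, the same change reads ethyl to hydroxymethyl. With no measured step of this kind in the series, the expectation rests on the change alone. A downward step beyond the scatter is expected, a number 1.00 log units lower from compound 2 to compound 4 (beyond the scatter). Compound 4 is accordingly estimated at 3.2, with a range from 2.7 to 3.7.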

Compound 4, distribution coefficient: 2.4
Beside the measured number, compound 4's estimate is 0.80 log units above it; the whole stated range lies above it.
By their numbers in this assay, from the lowest: compound 4; then compound 1; then compounds 3 and 2 (each within the scatter of the next).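

In this assay, the first step read in this series shows that this position is highly sensitive to the change, with a number 1.80 log units lower from compound 2 to compound 4 (beyond the scatter) for hydroxy in place of methyl on a saturated chain carbon bound to a saturated ring carbon. A large step therefore comes from exchanging a single heavy atom, with one hydrogen-bond donor and one hydrogen-bond acceptor entering and no ring or net charge involved. Nothing available here accounts for the size of this step.

This single pair leaves open whether a step of this size would recur with other amide groups on the shared core. Also open, going by these compounds, is where the read-out would fall with a methoxymethyl group, an aminomethyl group, a carboxylic acid or a longer chain such as propyl at this place.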